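This account rests on a few compounds, and the source may have more. Where it says the series, first, only, none or still open, it means among the compounds named here.

Three compounds share one core and differ in a single group: compound 1 (`COc1ccc(-c2c(C)nc3c(N4CC[C@@H](NC(C)=O)C4)cc(C)nn23)cc1OC`), compound 2 (`COc1ccc(-c2c(C)nc3c(N4CC[C@@H](NC(=O)NC(C)C)C4)cc(C)nn23)cc1OC`) and compound 3 (`COc1ccc(-c2c(C)nc3c(N4CC[C@@H](NC(=O)Oc5ccc6ccccc6c5)C4)cc(C)nn23)cc1OC`). All three were tested in an ADME assay on microsomes from liver (Homo sapiens) for metabolic stability, read by LC-MS, with NADPH named in the record, with a stated time of 60 min, tested at 1 uM, in the absence of a further agent (on this read-out higher numbers stand for a more stable compound and lower numbers for a less stable compound), and the results follow. Compound 2 gives > 95% here, and this is only a limit of the assay and not a number. Compound 1 gives > 95% as a limit too. Compound 3 gives > 95% as a limit too. Taken together, the evidence is the limit of > 95% in this assay, at which 3 of the 3 values shown sit, and no order among the three can be read from it.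

Compound 4 (`COc1ccc(-c2c(C)nc3c(N4CC[C@@H](NS(C)(=O)=O)C4)cc(C)nn23)cc1OC`) is still unmeasured. It differs from compound 2 by methylsulfonyl in place of isopropylcarbamoyl on an amine nitrogen. The measured steps that bear on this are a step that the two limits leave unreadable from compound 1 to compound 2 and a step that the two limits leave unreadable from compound 1 to compound 3 and a step that the two limits leave unreadable from compound 2 to compound 3 and none of them has a readable size. Each of them swaps a group on a carbonyl carbon, so they guide this change only loosely. With a step that the two limits leave unreadable from compound 2 to compound 3 as the closest guide, no change beyond the usual scatter is expected in this assay and neither direction is favoured. The estimate therefore means a number at least 2 percentage points lower from compound 2 to compound 4 (that floor lies within the scatter) as the expected step. Compound 4 is estimated at 93% with an expected range from 80% to 100%. Compound 4 may well yield only a limit.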

Compound 4, percent of the compound remaining: > 95%
Compound 4 was reported as a limit; the forecaster's own chance of this, stated with the estimate: 60%; middle value at least 2 percentage points away from the limit.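

In this assay compound 4 gives > 95%, and this is a limit and not a number. Within the data shown here, no step from compound 1 or compound 2 to compound 4 can be read, since the evidence is only a shared limit: the limit of > 95% in this assay, at which 4 of the 4 values shown sit. From the compounds shown here alone, whether compound 1, compound 2, compound 3 and compound 4 differ in stability at all, and in what order, stays open.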